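A few compounds are considered here, and "the series" means these few. Any claim that something is new, unique, unknown or untested is made for them only; others in the source may bear on it.

The study covers four compounds built on a shared core that carries an ethyl carbamate. Compound 1 `CCOC(=O)Nc1cc(N/N=C/c2ccccc2)c(N)c(N)n1` and compound 2 `CCOC(=O)Nc1cc(N/N=C/c2ccccc2)c2[nH]c(SCc3ccccc3)nc2n1` were both tested in a functional assay on L1210 cells (Mus musculus) for inhibition; on this read-out lower numbers stand for stronger inhibition and higher numbers for weaker inhibition. In this assay compound 1 gives 4600 nM. Among the measured compounds shown here, compound 2, which carries a benzylsulfanyl group, gives 46000 nM in this assay, a value that sits at weaker inhibition than the one for compound 1. Compound 3 `CCOC(=O)Nc1cc2c(nc(S)n2N)c(N)n1` bears a free sulfanyl group. For compound 3 this assay records only a limit, > 30000 nM, so no number is known for it (the limit of > 30000 nM in this assay, at which 1 of the 3 values shown sits). Compound 4 `CCOC(=O)Nc1cc2c(nc(SCc3ccccc3)n2N)c(N)n1` has not yet been measured in this assay. It differs from compound 3 in one place: benzyl in place of hydrogen on a sulfur. No measured pair among these compounds shows a step of this kind, and since compound 3 stands at a limit, no direction beyond the scatter can be read from the numbers. Compound 4 is therefore estimated at 40000 nM in this assay, within a range from 10000 nM to 150000 nM. The step implied is expected to be a step that the limit leaves unreadable from compound 3 to compound 4, with a real chance that only a limit is reported again.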

Compound 4, half-maximal inhibitory concentration: 600 nM
The estimate for compound 4 lay 67-fold (1.82 log units) above the measured number; the whole stated range lies above it.
By their numbers in this assay, from the lowest: compound 4; then compound 1; then compound 2.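

In this assay, benzyl in place of hydrogen on a sulfur gives an at least 50-fold lower number from compound 3 to compound 4 (1.69 log units; beyond the scatter). This is the only pair among the compounds shown that differs at this sulfur alone, so the change from sulfanyl to benzylsulfanyl now has a readable direction, towards stronger inhibition, on the core of compound 3. The full size of the step stays unknown, since its starting point is a limit and not a number: the limit of > 30000 nM in this assay, at which 1 of the 4 values shown sits.

The compounds shown do not tell whether a methyl group or a longer alkyl chain on this sulfur would serve as benzyl does, or whether the aromatic ring matters at all. They also leave open how a benzyl ring bearing a chlorine or a methoxy group would read out.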